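Swapping the piperazine substituent on the shared core

The source may report more compounds than this note shows. Statements on the series, on what has been measured and on what is new or still open speak of the compounds shown alone.

In an ADME assay on microsomes from liver (Homo sapiens) for metabolic stability, read by LC-MS, with a stated time of 10 min (a higher number here means that more of the compound is left, a lower number that less of the compound is left), compound 1 `CCCN(C[C@H]1Cc2c(cccc2N2CCNCC2)CN1)[C@H]1CCCc2cccnc21` gives 100% and compound 2 `C[C@@H]1CN(c2cccc3c2C[C@H](CN(C)[C@H]2CCCc4cccnc42)NC3)C[C@H](C)N1` gives 100%, level at the digits shown and together the highest of the three numbers. Among the measured compounds shown here, compound 3 `c1cnc2c(c1)CCC[C@@H]2N(CC1CCCCC1)C[C@H]1Cc2c(cccc2N2CCNCC2)CN1` gives 81.6%, and the one measured step, a number 18.4 percentage points lower from compound 1 to compound 3 (beyond the scatter), is a modest drop beyond the scatter. Compound 4 `CCN1CCN(c2cccc3c2C[C@H](CN(C)[C@H]2CCCc4cccnc42)NC3)CC1` differs from compound 2 by 4-ethylpiperazin-1-yl in place of 3,5-dimethylpiperazin-1-yl on an aromatic carbon. For the measured compounds named here, no measured step touches this change: the only step known concerns the saturated chain carbon bound to an amine nitrogen, not the aromatic carbon. Compound 4 is therefore expected to sit close to compound 2, with a small step of a number 8 percentage points lower from compound 2 to compound 4 (within the scatter), and its estimated value in this assay is 92%, ranging from 75% to 100%.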

Compound 4, percent of the compound remaining: 0%
Compound 4: middle estimate off by 92 percentage points, on the high side; the measured number lies below the stated range.
By their numbers in this assay, from the lowest: compound 4; then compound 3; then compounds 1 and 2 (each within the scatter of the next).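

On this aromatic carbon, the substituent on the piperazine can decide the outcome in this assay: 4-ethylpiperazin-1-yl in place of 3,5-dimethylpiperazin-1-yl gives a number 100 percentage points lower from compound 2 to compound 4 (beyond the scatter). The two groups match in heavy atoms and ring type, yet this large step exceeds the modest one seen earlier at the saturated chain carbon. No supporting data bear on the reason for the drop.

From the compounds shown here alone, whether the loss follows from adding the ethyl group or from removing the two methyl groups remains open. A 4-methylpiperazin-1-yl group or a morpholine on this carbon is also absent from the compounds shown.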